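The compounds below may be only part of what the source reports. "The series", "measured", "known", "first", "only" and "open" are said of these compounds alone.

In an ADME assay on microsomes from liver (Rattus norvegicus) for metabolic stability, tested at 2.5 uM (on this read-out lower numbers stand for slow clearance and higher numbers for fast clearance), the three measured compounds stand as follows:
compound 1 `O=S(=O)(c1ccc(F)c(F)c1)c1cnc2c(F)cccc2c1-c1ccc(Cl)cc1` gives 0.2 mL/min;
compound 2 `O=S(=O)(c1ccc(F)cc1)c1cnc2cc(Cl)c(F)cc2c1-c1ccc(Cl)cc1` gives 0.57 mL/min;
compound 3 `O=S(=O)(c1ccc(F)c(Cl)c1)c1cnc2cc(F)ccc2c1-c1ccc(Cl)cc1` gives 0.45 mL/min.

Compound 3 holds the second highest of these three numbers. Its nearest neighbour is compound 2, whose number lies within the scatter of its own, so no order between the two can be claimed; compound 1 lies beyond the scatter, at a lower number than compound 3. Compound 4 `O=S(=O)(c1cc(Cl)cc(Cl)c1)c1cnc2cc(F)ccc2c1-c1ccc(Cl)cc1` has not yet been measured. It differs from compound 3 in one place: 3,5-dichlorophenyl in place of 3-chloro-4-fluorophenyl on a sulfonyl sulfur. Going by the values given here, no pair of measured compounds shows this change by itself, so the expectation rests on compound 3 alone. The step of a 1.1-fold higher number from compound 3 to compound 4 (0.05 log units; within the scatter) is expected to stay within the scatter, without a clear direction. Compound 4 is estimated at 0.5 mL/min, with a range from 0.22 mL/min to 1.1 mL/min.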

Compound 4, intrinsic clearance in a liver preparation (reported as CLH), per the amount of preparation that the assay uses: 0.77 mL/min
Estimate against measurement, compound 4: 1.5-fold (0.19 log units) below; the range from low to high includes it.
By their numbers in this assay, from the lowest: compound 1; then compounds 3, 2 and 4 (each within the scatter of the next).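

In this assay the swap of 3-chloro-4-fluorophenyl for 3,5-dichlorophenyl on a sulfonyl sulfur gives a 1.7-fold higher number from compound 3 to compound 4 (0.23 log units; within the scatter) and so shows no clear change. Going by these compounds alone, this is the first direct look at this change, and at this place a fluorine can give way to a second chlorine without a shift beyond the usual scatter of repeated measurements. Nothing available here explains the result. Still open, going by these compounds, is whether a very different group on the sulfonyl sulfur, such as an amine or a carboxylic acid on the ring, would move the number clearly.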